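Compound 3 and a group swap in a cytotoxicity assay

The source may hold more compounds than are shown below. What is called first, only, known or untested is meant among the compounds shown, and "the series" means these compounds.

Measured in an ADME assay on Vero 76 cells (Chlorocebus sabaeus) for cytotoxicity, read by neutral red uptake (a higher number here means that more compound is tolerated, a lower number that less compound is tolerated), so far
- Compound 1 `CC(C)C(Nc1nc(Cl)nc2c1ncn2[C@H]1[C@H](O)[C@H](O)[C@]2(CO)C[C@H]12)C(C)C` gives > 100000 nM as a limit
- Compound 2 `OC[C@@]12C[C@@H]1[C@@H](n1cnc3c(NCc4ccccc4)nc(Cl)nc31)[C@H](O)[C@@H]2O` gives > 100000 nM as a limit
- Compound 3 `OC[C@@]12C[C@@H]1[C@@H](n1cnc3c(NC(C4CCC4)C4CCC4)nc(Cl)nc31)[C@H](O)[C@@H]2O` gives 28000 nM as a measured number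

Among the compounds with values here, compound 3 gives 28000 nM in this assay as the only true number and the lowest of the three. the limit of > 100000 nM in this assay, at which 2 of the 3 values shown sit, marks where compound 1 and compound 2 stand.

Compound 4 `CC(C)(O)[C@@H](Nc1nc(Cl)nc2c1ncn2[C@H]1[C@H](O)[C@H](O)[C@]2(CO)C[C@H]12)C1CC1` carries 1-cyclopropyl-2-hydroxy-2-methylpropyl in place of dicyclobutylmethyl on a nitrogen on an aromatic ring. The full count of that change is 1-cyclopropyl-2-hydroxy-2-methylpropyl in place of dicyclobutylmethyl on a nitrogen on an aromatic ring and the rest of the structure stays the same.

Within the data shown here, two measured steps bear on this change, an at least 3.5-fold lower number from compound 1 to compound 3 (0.55 log units; beyond the scatter) and an at least 3.5-fold lower number from compound 2 to compound 3 (0.55 log units; beyond the scatter) with dicyclobutylmethyl entering in both. Compound 4 loses that group, so a higher number is expected, by a step of at least modest size.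

In this assay the estimated step is a 3.2-fold higher number from compound 3 to compound 4 (0.51 log units; beyond the scatter) in that direction. For compound 4 the expected value is 90000 nM within an estimated range from 40000 nM to 200000 nM and a report of only a limit is quite possible.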

Compound 4, half-maximal cytotoxic concentration: > 100000 nM
Compound 4: a limit, no number (the forecaster's own chance of this, stated with the estimate: 65%); middle value at least 1.1-fold (0.04 log units) from the limit.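

In this assay, the change on the nitrogen gives an at least 3.5-fold higher number from compound 3 to compound 4 (0.55 log units; beyond the scatter). Within the data shown here, this is the third group at this position seen in place of dicyclobutylmethyl, and the first to carry a hydroxyl, and compound 3 remains the only compound of the four with a true number: the limit of > 100000 nM in this assay, at which 3 of the 4 values shown sit. The steps among compound 1, compound 2 and compound 4 cannot be read, since each of these compounds is reported only as a limit.

On these data alone, how much compound these three tolerate beyond the limit therefore stays open, and they cannot be ranked against one another. As far as these compounds go, it also remains open whether the lower number of compound 3 goes with its cyclobutyl rings or with the overall size of the group, a question that dicyclopropylmethyl or cyclobutylmethyl on the same nitrogen could help to separate.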